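A few compounds are considered here, and "the series" means these few. Any claim that something is new, unique, unknown or untested is made for them only; others in the source may bear on it.

Compound 1 `Cc1c(C(=O)/C=C/c2ccc(Cl)cc2)[n+]([O-])c2ccccc2[n+]1[O-]` is one of two compounds with a number in a functional assay on HSC-2 cells (Homo sapiens) for cytotoxicity, with a stated time of 48 h (a lower number here means that less compound is tolerated, a higher number that more compound is tolerated), where compound 1 gives 13000 nM. Compound 2 `COc1cc(/C=C/C(=O)c2c(C)[n+]([O-])c3ccccc3[n+]2[O-])cc(OC)c1OC` gives 7800 nM in this assay, and the two numbers lie within the usual scatter of each other, so neither stands apart from the other. Compound 3 `Cc1c(C(=O)/C=C/c2ccc(Br)cc2)[n+]([O-])c2ccccc2[n+]1[O-]` carries bromo in place of chloro on an aromatic carbon, a bromo in place of chloro on an aromatic carbon. For so small a change he expects no step beyond the scatter, with a 1.1-fold lower number from compound 1 to compound 3 (0.03 log units; within the scatter) as the expected step. Compound 3 is therefore estimated at 12000 nM, ranging from 6000 nM to 25000 nM.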

Compound 3, half-maximal cytotoxic concentration: 19000 nM
The estimate for compound 3 lay 1.6-fold (0.20 log units) below the measured number; low and high end bracket the measured number.
By their numbers in this assay, from the lowest: compounds 2, 1 and 3 (each within the scatter of the next, the first and the last beyond it).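

In this assay, among the compounds shown here, bromo in place of chloro gives a 1.5-fold higher number from compound 1 to compound 3 (0.16 log units; within the scatter), the first comparison here that differs in one place only. On this aromatic carbon, para to a large group, the two halogens therefore cannot be told apart in this assay. Nothing at hand offers an explanation for this result.

Going by these compounds, whether this position tolerates a group other than a halogen remains open. An amine or a carboxylic acid on this carbon, for instance, might move the number beyond the scatter, or might not.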